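Notes on the step from compound 2 to compound 3

The source may hold more compounds than are shown below. What is called first, only, known or untested is meant among the compounds shown, and "the series" means these compounds.

Among the measured compounds shown here, in a functional assay on RS4-11 cells (Homo sapiens) for inhibition, read by CCK-8 assay, with a stated time of 48 h, tested at 20 uM (on this read-out lower numbers stand for less inhibition of growth and higher numbers for more inhibition of growth at the one concentration tested), compound 2 (`Cc1ccc(S(=O)(=O)Oc2ccccc2/C=C(\C#N)C(=O)Nc2nnc(Cc3cccc(F)c3)s2)cc1`) gives 56% as the lower of the two numbers so far. Against that, compound 1 (`N#C/C(=C\c1ccccc1OS(=O)(=O)c1ccc(F)cc1)C(=O)Nc1nnc(Cc2ccccc2)s1`) stands at 69% and the gap lies beyond the scatter. Compound 3 (`N#C/C(=C\c1ccccc1OS(=O)(=O)c1ccc(F)cc1)C(=O)Nc1nnc(Cc2cccc(F)c2)s1`) differs from compound 2 by fluoro in place of methyl on an aromatic carbon, para to a large group (fluoro in place of methyl on an aromatic carbon). For the measured compounds named here, no step between measured compounds isolates this change, so the expectation rests on thin evidence. Compound 1 at 69% also carries (4-fluorophenyl)sulfonyl, which points to a small upward step in this assay that is expected to stay within the scatter. The expected size of the change (a number 6 percentage points higher from compound 2 to compound 3 (within the scatter)) is only an estimate. The estimated value for compound 3 is 62% within an expected range (48% to 76%).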

Compound 3, percent growth inhibition at one concentration: 72%
Estimate against measurement, compound 3: 10 percentage points below; measured number inside the range.
By their numbers in this assay, from the lowest: compound 2; then compounds 1 and 3 (each within the scatter of the next).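

In this assay, among the compounds shown here, the change from (4-methylphenyl)sulfonyl to (4-fluorophenyl)sulfonyl gives a number 16 percentage points higher from compound 2 to compound 3 (beyond the scatter), the first reading that isolates fluoro in place of methyl on this aromatic carbon, para to a large group. Fluoro in place of hydrogen on an aromatic carbon elsewhere in the molecule gives a number 3 percentage points higher from compound 1 to compound 3 (within the scatter), so this second change has no readable effect at the one concentration tested. No data on the compounds offer an explanation for the step at the (4-fluorophenyl)sulfonyl position.

From the compounds shown here alone, whether the same position gives similar growth inhibition with a chloro, a methoxy or an amine remains open. Going by these compounds, the fluoro-for-methyl step also rests on one pair, so whether it carries over to the hydrogen-bearing ring of compound 1 remains unknown.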